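Series notes: ether side chain on the chlorophenyl oxygen

The compounds below may be only part of what the source reports. "The series", "measured", "known", "first", "only" and "open" are said of these compounds alone.

Measured compounds in a functional assay for inhibition of transient receptor potential cation channel subfamily V member 1 (Homo sapiens), read by fluorescence and calcium flux; a lower number here means a stronger inhibitor, a higher number a weaker inhibitor:
compound 1 `Cc1nc(O)c2cc(-c3ccc(Cl)c(OCC(=O)O)c3)c(C(C)C)cc2n1`: a limit, > 1000 nM
compound 2 `COCCOc1cc(-c2cc3c(O)nc(C)nc3cc2C(C)C)ccc1Cl`: 216 nM
compound 3 `Cc1nc(O)c2cc(-c3ccc(Cl)c(OCCO)c3)c(C(C)C)cc2n1`: 557 nM

Among the measured compounds shown here, compound 3 gives the highest of the two numbers known in this assay; its nearest neighbour is compound 2, and the step of a 2.6-fold higher number from compound 2 to compound 3 (0.41 log units; beyond the scatter) lies beyond the scatter. For compound 1 this assay reports only a limit, > 1000 nM. The steps from that limit, an at least 4.6-fold lower number from compound 1 to compound 2 (0.66 log units; beyond the scatter) and an at least 1.7-fold lower number from compound 1 to compound 3 (0.25 log units; that floor lies within the scatter), point the same way.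

Compound 4 `Cc1nc(O)c2cc(-c3ccc(Cl)c(OC(C)C)c3)c(C(C)C)cc2n1` differs from compound 3 by isopropyl in place of 2-hydroxyethyl on an oxygen on an aromatic ring. The bearing steps are those along the chain: carboxy to hydroxymethyl to methoxymethyl gave progressively lower numbers, the last of them a 2.6-fold higher number from compound 2 to compound 3 (0.41 log units; beyond the scatter) read backwards. Compound 4 continues in that direction, so a lower number in this assay than compound 3 is expected, of a size similar to the step to compound 2 or somewhat larger. Compound 4 is therefore estimated at 200 nM, within 70 nM to 600 nM, which means an expected step of a 2.8-fold lower number from compound 3 to compound 4 (0.44 log units; beyond the scatter).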

Compound 4, half-maximal inhibitory concentration: 201 nM
Beside the measured number, compound 4's estimate is 1.0-fold (0.00 log units) below it; measured number inside the range.
By their numbers in this assay, from the lowest: compounds 4 and 2 (each within the scatter of the next); then compound 3. At a limit, above all of these: compound 1.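

Isopropyl in place of 2-hydroxyethyl on an oxygen on an aromatic ring gives a 2.8-fold lower number from compound 3 to compound 4 (0.44 log units; beyond the scatter) in this assay, so a hydrogen-bond donor on this side chain is not required for the lower number. Isopropyl in place of 2-methoxyethyl gives a 1.1-fold lower number from compound 2 to compound 4 (0.03 log units; within the scatter), so the chain oxygen of the 2-methoxyethyl group is not required either, and a side chain of carbon alone serves as well. The step from the carboxymethyl group, an at least 4.9-fold lower number from compound 1 to compound 4 (0.69 log units; beyond the scatter), starts from a limit for compound 1: the limit of > 1000 nM in this assay, at which 1 of the 4 values shown sits.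

Open, on these data alone, is whether any group on this oxygen moves the number clearly beyond the level shared by compound 2 and compound 4. A methyl, a longer chain such as n-butyl, a cyclopropylmethyl group or a 2-aminoethyl chain would test this.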